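Methoxy for fluoro on the pendant aryl of compound 3

The source may report more compounds than this note shows. Statements on the series, on what has been measured and on what is new or still open speak of the compounds shown alone.

Among the three compounds measured in a functional assay on MCF7 cells (Homo sapiens) for cytotoxicity, read by MTT assay, with a stated time of 2 days, tested at 10 uM (on this read-out higher numbers stand for a weaker effect at the one concentration tested and lower numbers for a stronger effect), compound 3 `COc1ccc(-c2cc3cc(-c4ccc(F)cc4)cc(C(C)=O)c3[nH]2)cc1` gives 77.5%, the highest of the three numbers. Compound 2 `COc1ccc(-c2cc3cc(-c4ccccc4)cc(C(C)=O)c3[nH]2)cc1` gives 64.5%, and compound 1 `COc1ccc(-c2cc(C(C)=O)c3[nH]c(-c4ccccc4)cc3c2)cc1` gives 49.5%. The one single-place step among these, a number 13 percentage points higher from compound 2 to compound 3 (beyond the scatter), is the only measured step at the position in question.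

Compound 4 `COc1ccc(-c2cc(C(C)=O)c3[nH]c(-c4ccc(OC)cc4)cc3c2)cc1` differs from compound 3 by methoxy in place of fluoro on an aromatic carbon. Among the compounds with values here, no measured step shows a methoxy taking the place of a fluoro, so the data give no direct guide to the size or direction of this change; the step from compound 2 to compound 3 shows only that a substituent at this place shifted the number, and a different group may shift it otherwise. Compound 4 is therefore expected to land near compound 3, with the estimated step of a number 5.5 percentage points lower from compound 3 to compound 4 (within the scatter) lying inside the scatter. The estimate for compound 4 is 72%, within a range from 52% to 90%.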

Compound 4, a percentage reported as activity, at one concentration (the size of the read-out at that concentration, not a potency): 56.4%
The estimate for compound 4 lay 15.6 percentage points above the measured number; the range from low to high includes it.
By their numbers in this assay, from the lowest: compounds 1, 4 and 2 (each within the scatter of the next, the first and the last beyond it); then compound 3.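

In this assay, within the data shown here, the exchange of fluoro for methoxy gives a number 21.1 percentage points lower from compound 3 to compound 4 (beyond the scatter) on the pendant aryl, so this position responds to which group it carries and not merely to whether it carries one, which the single earlier step could not show. Methoxy in place of hydrogen gives a number 8.1 percentage points lower from compound 2 to compound 4 (within the scatter) and a number 6.9 percentage points higher from compound 1 to compound 4 (within the scatter) in the two comparisons with the unsubstituted phenyl compounds, while fluoro in place of hydrogen gave a number 13 percentage points higher from compound 2 to compound 3 (beyond the scatter) as the only one of these hydrogen replacements beyond the scatter. Nothing measured here accounts for the difference between the two groups.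

As far as these compounds go, whether an amine, a carboxylic acid or a longer alkoxy chain at this place would follow fluoro or methoxy stays open. So does whether fluoro would shift the number in the same way on the core of compound 1.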